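Branching the chain of compound 2: one ethyl added

A few compounds are considered here, and "the series" means these few. Any claim that something is new, unique, unknown or untested is made for them only; others in the source may bear on it.

Measured compounds:
compound 1, `O=C(O)c1ccccc1-c1ccc(CCc2ncc(CC3CCCCC3)[nH]2)cc1`: 41 nM
compound 2, `CCCCc1cnc(C(C)Cc2ccc(-c3ccccc3C(=O)O)cc2)[nH]1`: 2760 nM

In an in vitro functional assay on cells for agonist activity at Bombesin receptor subtype-3 (Homo sapiens), read by luminescence and calcium flux (on this read-out higher numbers stand for an effect only at larger amounts of compound and lower numbers for an effect already at smaller amounts), compound 2 gives 2760 nM, the highest of the two numbers, while compound 1 gives 41 nM; the gap between them lies beyond the scatter. Compound 3, `CCCCc1cnc(C(CCC)Cc2ccc(-c3ccccc3C(=O)O)cc2)[nH]1`, differs from compound 2 by ethyl in place of hydrogen on a saturated chain carbon, two bonds along the chain from an aromatic carbon. Going by the values given here, no measured pair shows the effect of such a change, so a step within the scatter is expected, with no clear direction. The estimate for compound 3 in this assay is 2000 nM, between 500 nM and 8000 nM, meaning an expected step of a 1.4-fold lower number from compound 2 to compound 3 (0.14 log units; within the scatter).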

Compound 3, half-maximal effective concentration: 1180 nM
Compound 3: the middle estimate sits 1.7-fold (0.23 log units) above what was measured, and the stated range covers the measured number.
By their numbers in this assay, from the lowest: compound 1; then compound 3; then compound 2.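

Read as methyl to propyl, the change brings a 2.3-fold lower number from compound 2 to compound 3 (0.37 log units; beyond the scatter) in this assay, so this saturated chain carbon tolerates a longer branch and lower numbers are reachable there. Going by these compounds alone, the first comparison at this position thus shows that the added ethyl does not raise the number. No measurement here explains why the number falls. As far as these compounds go, whether the trend continues with a longer chain such as butyl remains open. So does the outcome of placing an amine or a hydroxyl group on this same carbon.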